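The source may report more compounds than this note shows. Statements on the series, on what has been measured and on what is new or still open speak of the compounds shown alone.

Working notes on a small series built on one shared core. Compound 1 `CC(=O)N1N=C(c2cc3ccccc3nc2C)CC1c1ccc(C#N)cc1` was examined in an ADME assay on A549 cells (Homo sapiens) for cytotoxicity, read by MTT assay, with a stated time of 48 h; on this read-out lower numbers stand for stronger inhibition and higher numbers for weaker inhibition. In this assay compound 1 gives only a limit, > 200 ug/mL, and no number is known for it. Compound 2 `Cc1nc2ccccc2cc1-c1nnc(-c2ccccc2C(=O)O)o1` carries a different arrangement on the same core; in this assay compound 2 gives 106 ug/mL. Compound 1 therefore stands at the limit of > 200 ug/mL in this assay, at which 1 of the 2 values shown sits, so its position among the numbers shown is bounded from one side only. Compound 3 `COc1ccc(C2CC(c3cc4ccccc4nc3C)=NN2C(C)=O)cc1` has not yet been measured. It differs from compound 1 by methoxy in place of cyano on an aromatic carbon. Going by the values given here, no measured step of this kind is available, so the size of the step is open; no change beyond the scatter is expected in this assay. Compound 3 is expected to give 200 ug/mL, between 90 ug/mL and 400 ug/mL. The expected step from compound 1 to compound 3 is accordingly a number no higher from compound 1 to compound 3 (the limit leaves the size open), within the scatter, and a limit again is the likeliest outcome.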

Compound 3, half-maximal inhibitory concentration: 116 ug/mL
Beside the measured number, compound 3's estimate is 1.7-fold (0.24 log units) above it, and the stated range covers the measured number.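

In this assay, going by these compounds alone, the change from 4-cyanophenyl to 4-methoxyphenyl gives an at least 1.7-fold lower number from compound 1 to compound 3 (0.23 log units; that floor lies within the scatter), the only step that can be read at this position on the shared core. Compound 3 supplies a measured number for this aromatic position, which compound 1 could not provide. The full size of the step remains open because the reading for compound 1 is a limit, not a number: the limit of > 200 ug/mL in this assay, at which 1 of the 3 values shown sits.

On these data alone, whether another group at this position, such as an amine, a hydroxyl or a longer alkoxy chain, would give a step beyond the scatter remains open. One bounded step supports no trend across groups at this position, and it does not show whether methoxy would behave the same way elsewhere on the same aromatic ring.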